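Swapping a methyl for a fluoro on a sulfonamide aryl ring

A few compounds are considered here, and "the series" means these few. Any claim that something is new, unique, unknown or untested is made for them only; others in the source may bear on it.

Measured so far:
Compound 1 `Cc1ccc(S(=O)(=O)Nc2ccc(-c3nc4ccccc4o3)cc2)cc1`: 88000 nM
Compound 2 `COc1ccccc1S(=O)(=O)Nc1ccc2oc(-c3ccccc3)nc2c1`: 41000 nM

Both compounds were tested in an ADME assay on HEK293 cells (Homo sapiens) for cytotoxicity, read by resazurin assay, with a stated time of 48 h; a lower number here means that less compound is tolerated, a higher number that more compound is tolerated. Compound 1 gives 88000 nM, the higher of the two numbers, so it is the better tolerated of the pair. Compound 2 gives 41000 nM, a number that sits beyond the usual scatter below that of compound 1. The two compounds differ in several places at once, so nothing can be said about which part of the structure accounts for the gap.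

The next compound, compound 3 `O=S(=O)(Nc1ccc(-c2nc3ccccc3o2)cc1)c1ccc(F)cc1`, is not yet measured. It differs from compound 1 in a single place: fluoro in place of methyl on an aromatic carbon. Cut one bond further out, the same change reads 4-methylphenyl to 4-fluorophenyl. The shared core, the sulfonamide link and the rest of the molecule stay the same.

Among the measured compounds shown here, with no measured step between two compounds that differ in this way, there is nothing to anchor a direction. A change of one heavy atom for one heavy atom on an aromatic carbon is expected to move the number little, if at all, so the step of a 1.1-fold lower number from compound 1 to compound 3 (0.04 log units; within the scatter) is expected to stay within the scatter. Compound 3 is therefore estimated at 80000 nM, with a range from 40000 nM to 160000 nM.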

Compound 3, half-maximal cytotoxic concentration: > 100000 nM
Compound 3: a limit, no number; the forecaster's own chance of this, stated with the estimate: 10%; middle value at least 1.2-fold (0.09 log units) from the limit.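

In this assay compound 3 gives > 100000 nM, which is a limit of the assay and not a number. Among the compounds shown here, this is the first comparison in which only one group changes, and fluoro in place of methyl on this aromatic carbon, para to a large group, gives an at least 1.1-fold higher number from compound 1 to compound 3 (0.05 log units; that floor lies within the scatter), so the swap does not lower the number here, although the floor of the step does not show a real rise. The true size of the step cannot be read, and any rise may be small or large, because the value of compound 3 stands at the edge of what the assay reports: the limit of > 100000 nM in this assay, at which 1 of the 3 values shown sits.

From the compounds shown here alone, how a larger halogen such as chloro, or an amine or a carboxylic acid, would behave on this same ring carbon remains open. Also open, going by these compounds, is whether this swap would give a similar result on a different core, and compound 2 cannot help with either question, since it differs from compound 1 and compound 3 in several places at once.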